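The source may report more compounds than this note shows. Statements on the series, on what has been measured and on what is new or still open speak of the compounds shown alone.

Compound 1, `CC(C)(C)c1conc1N1C(=O)CSC1c1cccc(C(=O)NCCCCc2ccccc2)c1`, is the starting point of this step. In a functional assay on HOS-TE85 cells (Homo sapiens) for inhibition, read by CCK-8 assay, with a stated time of 72 h (on this read-out higher numbers stand for weaker inhibition and lower numbers for stronger inhibition), compound 1 gives > 1000 nM, which is a limit of the assay rather than a measured number. Compound 2, `COc1ccccc1N1C(=O)CSC1c1cccc(C(=O)NCCCCN2C(=O)C=CC2=O)c1`, also sits at a limit: in this assay compound 2 gives > 1000 nM. Only compound 3, `COc1ccccc1N1C(=O)CSC1c1cc(C)cc(C(=O)NCCCCc2ccccc2)c1`, gives a measured value; in this assay compound 3 gives 16.2 nM. So compound 1 stands at the limit of > 1000 nM in this assay, at which 2 of the 3 values shown sit, and no measured step between compounds is available.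

Compound 4, `Cc1cccc(N2C(=O)CSC2c2cccc(C(=O)NCCCCc3ccccc3)c2)c1`, differs from compound 1 in one place: a group of 7 heavy atoms (7 carbon; one six-membered aromatic ring of carbon only) in place of a group of 9 heavy atoms (7 carbon, 1 nitrogen, 1 oxygen; one five-membered aromatic ring with 2 hetero atoms), on an amide-type nitrogen in a ring. The new compound keeps the phenylbutyl amide of compound 1 and carries an aromatic carbon ring on the ring nitrogen, as compound 3 does; compound 3 is expected to be the closest guide, though it also carries a methyl on its central ring.

On that basis compound 4 is expected to show inhibition well beyond the scatter, as the step of an at least 10-fold lower number from compound 1 to compound 4 (1.00 log units; beyond the scatter) expresses. For compound 4 in this assay the estimate is 100 nM, with a range from 20 nM to 600 nM.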

Compound 4, half-maximal inhibitory concentration: 93.2 nM
Beside the measured number, compound 4's estimate is 1.1-fold (0.03 log units) above it, within the range that was stated.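

In this assay, placing 3-methylphenyl on the amide-type nitrogen in a ring, where the five-membered aromatic ring group stood, gives an at least 10-fold lower number from compound 1 to compound 4 (1.03 log units; beyond the scatter). This is the first step shown at this place, and since the rest of the molecule stays the same, the change of this one group is enough to bring a value within the measured range. Compound 1 has only a limit rather than a number, so the step gives a minimum and its full size stays unknown: the limit of > 1000 nM in this assay, at which 2 of the 4 values shown sit.

Compound 3 and compound 4 differ in more than one place, so their values cannot separate the effect of either change. Going by these compounds, it also remains open how an unsubstituted phenyl, a pyridine ring or a cyclohexyl ring on this nitrogen would compare with 3-methylphenyl.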